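Shared core, hydroxy to amino exchange on an aromatic carbon

This account rests on a few compounds, and the source may have more. Where it says the series, first, only, none or still open, it means among the compounds named here.

Compound 2 `Nc1nc(O)c2nnn([C@H]3CCC[C@H]3CO)c2n1` gives 86000 nM in a functional assay on MOLT-4 cells (Homo sapiens) for antiproliferative activity; on this read-out lower numbers stand for stronger inhibition and higher numbers for weaker inhibition. Among the three measured numbers it stands second highest: compound 1 `Nc1nc(Cl)c2nnn([C@H]3CCC[C@H]3CO)c2n1` gives 75300 nM and compound 3 `Nc1nc(N)c2ncn([C@H]3CCC[C@H]3CO)c2n1` gives 147000 nM, both within the scatter of compound 2. Among the measured compounds shown here, the single one-point step measured so far, a 1.1-fold higher number from compound 1 to compound 2 (0.06 log units; within the scatter), lies within the scatter. Compound 4 `Nc1nc(N)c2nnn([C@H]3CCC[C@H]3CO)c2n1` is not yet measured; it differs from compound 2 by amino in place of hydroxy on an aromatic carbon. For the measured compounds named here, no measured step exchanges hydroxy for amino. Going by the values given here, compound 3 also bears an amino group, but on a core that is not the shared core of compounds 1, 2 and 4, so it offers no direct step. Among the compounds with values here, the only step with any bearing, a 1.1-fold higher number from compound 1 to compound 2 (0.06 log units; within the scatter), was within the scatter, and all three values cluster closely; the step from compound 2 to compound 4 in this assay is therefore expected to be a 1.1-fold higher number from compound 2 to compound 4 (0.04 log units; within the scatter), none beyond the scatter. Compound 4 is estimated at 95000 nM, with a range from 40000 nM to 230000 nM.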

Compound 4, half-maximal inhibitory concentration: 120000 nM
The estimate for compound 4 lay 1.3-fold (0.10 log units) below the measured number; the range from low to high includes it.
By their numbers in this assay, from the lowest: compounds 1, 2, 4 and 3 (each within the scatter of the next).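

In this assay the shared core now carries three different groups at the aromatic carbon opposite the ring nitrogen: chloro, hydroxy and amino. Amino in place of hydroxy gives a 1.4-fold higher number from compound 2 to compound 4 (0.14 log units; within the scatter) and amino in place of chloro gives a 1.6-fold higher number from compound 1 to compound 4 (0.20 log units; within the scatter), so the amino group joins the earlier chloro and hydroxy pair, and no exchange among the three at this position reaches beyond the scatter. No measurement on hand accounts for these values.

Going by these compounds, whether a methoxy group, a dimethylamino group or a longer alkyl chain at this position would give a step beyond the scatter remains open. Also open, on these data alone, is whether any of these exchanges would read the same way on a different core.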